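The source may hold more compounds than are shown below. What is called first, only, known or untested is meant among the compounds shown, and "the series" means these compounds.

The series shares one core, varied at a single aromatic carbon. Compound 1 `COC(=O)/C=C/c1cccc(N(Cc2ccc(/C=C/c3scnc3C)cc2)C(=O)C2CCCCC2)c1` gives 227 nM in an assay on isolated protein with Bile acid receptor (Homo sapiens) as the target; on this read-out higher numbers stand for an effect only at larger amounts of compound and lower numbers for an effect already at smaller amounts. Compound 2 `CCOc1cccc(-c2ccc(CN(C(=O)C3CCCCC3)c3cccc(/C=C/C(=O)OC)c3)cc2)c1` gives 147 nM in this assay, and compound 3 `COC(=O)/C=C/c1cccc(N(Cc2ccc(-c3cccc(Cl)c3)cc2)C(=O)C2CCCCC2)c1` gives 94 nM in this assay. Compound 3 has the lowest number of the three, but its separation from compound 2 is only a 1.6-fold lower number from compound 2 to compound 3 (0.19 log units; within the scatter), while a 2.4-fold lower number from compound 1 to compound 3 (0.38 log units; beyond the scatter) does set it apart from compound 1. The step of a 1.5-fold lower number from compound 1 to compound 2 (0.19 log units; within the scatter) adds no separation between those two.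

Compound 4 `COC(=O)/C=C/c1cccc(N(Cc2ccc(-c3cccc(C)c3)cc2)C(=O)C2CCCCC2)c1` is not yet measured. Against compound 3 the change is methyl in place of chloro on an aromatic carbon. Within the data shown here, no measured pair makes this exact swap; the only step bearing on it is a 1.6-fold lower number from compound 2 to compound 3 (0.19 log units; within the scatter), an exchange of two small groups at the same aromatic carbon that did not move the number beyond the scatter. The step of a 1.2-fold higher number from compound 3 to compound 4 (0.07 log units; within the scatter) is therefore expected to stay within the scatter. The estimate for compound 4 in this assay is 110 nM, with a range from 55 nM to 230 nM.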

Compound 4, half-maximal effective concentration: 109 nM
Estimate against measurement, compound 4: 1.0-fold (0.00 log units) above, and the stated range covers the measured number.
By their numbers in this assay, from the lowest: compounds 3, 4, 2 and 1 (each within the scatter of the next, the first and the last beyond it).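

The exact swap of chloro for methyl, one heavy atom for one heavy atom on an aromatic carbon meta to a large group, can now be read directly in this assay: a 1.2-fold higher number from compound 3 to compound 4 (0.06 log units; within the scatter). With a 1.3-fold lower number from compound 2 to compound 4 (0.13 log units; within the scatter) also inside the scatter, the 3-chlorophenyl, 3-methylphenyl and 3-ethoxyphenyl groups are not told apart here, whereas a 2.1-fold lower number from compound 1 to compound 4 (0.32 log units; beyond the scatter) gives a second modest separation from the 2-(4-methyl-1,3-thiazol-5-yl)ethenyl group of compound 1, a pattern that compound 2 goes against with a 1.5-fold lower number from compound 1 to compound 2 (0.19 log units; within the scatter). Nothing available here points to a cause for these steps.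

Open, on these data alone, is whether an amine or a carboxylic acid at this aromatic carbon, or a chain longer than ethoxy, would move the number beyond the scatter. Also open, as far as these compounds go, is whether chloro and methyl read alike elsewhere on the shared core.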